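A few compounds are considered here, and "the series" means these few. Any claim that something is new, unique, unknown or untested is made for them only; others in the source may bear on it.

Three amides built on one shared core have been tested for how strongly they harm human THP-1 cells in an ADME assay on THP-1 cells (Homo sapiens) for cytotoxicity, read by WST assay, with a stated time of 24 h; a higher number here means a weaker inhibitor, a lower number a stronger inhibitor. Compound 1, `O=C(Nc1ccccc1Br)c1ccc2cccc(O)c2n1`, carries a 2-bromophenyl on its amide-type nitrogen. In this assay compound 1 gives only a limit, > 30000 nM. Compound 2, `O=C(Nc1ccc(Br)cc1)c1ccc2cccc(O)c2n1`, has the same atoms joined differently, (4-bromophenyl in place of 2-bromophenyl on an amide-type nitrogen). In this assay compound 2 likewise gives only a limit, > 30000 nM. Compound 3, `O=C(Nc1ccccc1C(F)(F)F)c1ccc2cccc(O)c2n1`, differs from compound 1 by trifluoromethyl in place of bromo on an aromatic carbon. In this assay compound 3 also gives only a limit, > 30000 nM.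

The step that the two limits leave unreadable from compound 1 to compound 2 cannot be read, and the same holds for a step that the two limits leave unreadable from compound 1 to compound 3, because of the limit of > 30000 nM in this assay, at which 3 of the 3 values shown sit. So far no compound in this series has shown measurable toxicity toward these cells.

Compound 4, `O=C(Nc1ccc(C(F)(F)F)cc1)c1ccc2cccc(O)c2n1`, is not yet measured. It differs from compound 2 by trifluoromethyl in place of bromo on an aromatic carbon. Among the measured compounds shown here, this is the same kind of change as the one from compound 1 to compound 3, though the place is not identical: in compound 3 the trifluoromethyl sits ortho to a large group, while in compound 4 it sits para to a large group.

Since all three measured values sit at the limit, the step of a number no higher from compound 2 to compound 4 (the limit leaves the size open) is expected to be a flat one, mirroring the unreadable a step that the two limits leave unreadable from compound 1 to compound 3, and compound 4 is estimated at 30000 nM, most likely reported again only as a limit.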

Compound 4, half-maximal inhibitory concentration: > 30000 nM
Compound 4: no number, only a limit; the forecaster's own chance of this, stated with the estimate: 85%; the middle value lies on the limit itself.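

The step from compound 2 to compound 4 cannot be read, because compound 2 and compound 4 each give only a limit, as do compound 1 and compound 3: the limit of > 30000 nM in this assay, at which 4 of the 4 values shown sit.

The compounds shown leave open how strongly any of these amides harms the cells, and whether trifluoromethyl in place of bromo makes any difference to that harm.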